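Dropping the Carbamate from a Diaziridinyl Quinone

The source may hold more compounds than are shown below. What is called first, only, known or untested is meant among the compounds shown, and "the series" means these compounds.

Measured compounds:
compound 1 `CCC1=C(N2CC2)C(=O)C(CCOC(N)=O)=C(N2CC2)C1=O` gives 4.88
compound 2 `CCCC1=C(N2CC2)C(=O)C(CCOC(N)=O)=C(N2CC2)C1=O` gives 4.42
compound 3 `CCOC(COC(N)=O)C1=C(N2CC2)C(=O)C(CC)=C(N2CC2)C1=O` gives 4.64

In a functional assay on L1210 cells (Mus musculus), with a stated time of 1 days (a lower number here means a less potent compound, a higher number a more potent compound, by a factor of ten per unit of this negative logarithm), compound 1 stands highest of the three; compound 3 lies nearest, a difference within the usual scatter, and compound 2 lies furthest, with a number 0.46 log units lower from compound 1 to compound 2 (beyond the scatter).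

Compound 4 `CCC1=C(N2CC2)C(=O)C(CC)=C(N2CC2)C1=O` differs from compound 1 by hydrogen in place of carbamoyloxy on a saturated chain carbon, two bonds along the chain from a double-bonded ring carbon. For the measured compounds named here, neither measured step removes this group: the step of a number 0.46 log units lower from compound 1 to compound 2 (beyond the scatter) alters a chain carbon, and the step of a number 0.24 log units lower from compound 1 to compound 3 (within the scatter) adds ethoxy, so no step bears directly. Both were flat or downward, so a modest drop is expected. Compound 4 is estimated at 4.5, between 3.9 and 5.1, a step of a number 0.38 log units lower from compound 1 to compound 4 (beyond the scatter).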

Compound 4, logarithm of the reciprocal of the active concentration, log(1/C): 4.79
Compound 4: the middle estimate sits 0.29 log units below what was measured, within the range that was stated.
By their numbers in this assay, from the lowest: compounds 2, 3, 4 and 1 (each within the scatter of the next, the first and the last beyond it).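

Putting hydrogen in place of carbamoyloxy on this saturated chain carbon gives a step in this assay of a number 0.09 log units lower from compound 1 to compound 4 (within the scatter). Within this pair, then, 2-(carbamoyloxy)ethyl and ethyl cannot be told apart, so the whole carbamoyloxy group can go without a measurable change in this read-out. Nothing at hand explains why.

Still open, as far as these compounds go, is whether other groups at this place, such as an amine or a carboxylic acid, would also stay level with compound 1. From the compounds shown here alone, a longer chain ending in carbamoyloxy is equally open.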